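A few compounds are considered here, and "the series" means these few. Any claim that something is new, unique, unknown or untested is made for them only; others in the source may bear on it.

In a functional assay on MDA-MB-436 cells (Homo sapiens) for antiproliferative activity, read by MTT assay, with a stated time of 48 h (a lower number here means a stronger inhibitor, a higher number a weaker inhibitor), compound 3 `CN1CCN(c2ccc(-c3cc4c(N5CCN(S(=O)(=O)/C=C/c6ccccc6)CC5)ncnc4s3)cc2)CC1` gives 8670 nM. Compound 1 `C=CS(=O)(=O)N1CCN(c2ncnc3sc(-c4ccc(N5CCN(C)CC5)cc4)cc23)CC1` gives 8760 nM, which is level with compound 3 within the scatter. Compound 2 `C=CS(=O)(=O)N1CCN(c2ncnc3sc(-c4cc(Br)cnc4F)cc23)CC1` has a clearly higher number at 28400 nM, but it carries a different group on the shared core, so it says little about the sulfonyl side.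

The unmeasured compound 4 `CCS(=O)(=O)N1CCN(c2ncnc3sc(-c4ccc(N5CCN(C)CC5)cc4)cc23)CC1` differs from compound 3 in one place, with ethyl in place of 2-phenylethenyl on a sulfonyl sulfur. Among the compounds with values here, only one measured step bears directly on this change. Exchanging vinyl for 2-phenylethenyl on the same sulfur gave a 1.0-fold lower number from compound 1 to compound 3 (0.00 log units; within the scatter). As far as these compounds go, that single pair shows no response to the exchange at this place, although the data hold no measurement of a sulfonyl group without a double bond, so ethyl remains untested here. The expectation therefore follows compound 1 and compound 3, with no shift beyond the scatter and no firm direction. The expected step is a 1.1-fold higher number from compound 3 to compound 4 (0.04 log units; within the scatter). For compound 4 the estimated value is 9500 nM, with an expected range of 4500 nM to 20000 nM.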

Compound 4, half-maximal inhibitory concentration: 10600 nM
Compound 4: middle estimate off by 1.1-fold (0.05 log units), on the low side, and the stated range covers the measured number.
By their numbers in this assay, from the lowest: compounds 3, 1 and 4 (each within the scatter of the next); then compound 2.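

In this assay, replacing 2-phenylethenyl with ethyl on the sulfonyl sulfur gives a 1.2-fold higher number from compound 3 to compound 4 (0.09 log units; within the scatter), and replacing vinyl with ethyl gives a 1.2-fold higher number from compound 1 to compound 4 (0.08 log units; within the scatter), both within the scatter. Within the data shown here, the earlier pair had compared only two groups that each carry a double bond outside aromatic rings, whereas ethyl has neither that double bond nor a ring. Among these three compounds, therefore, neither feature is needed to hold the number at this level, and the position has so far shown no response to a substituent of any of these sizes, although nothing available explains that flat response.

As far as these compounds go, it remains open whether this position responds at all to a group of another kind, such as a longer chain ending in an amine, a carboxylic acid, or a methyl on the sulfonyl sulfur. From the compounds shown here alone, it is also open whether ethyl would behave the same way on the core of compound 2, which carries the bromo-fluoro ring in place of the methylpiperazine-bearing phenyl group.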